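Bromo to methylamino at the limit of the assay

A few compounds are considered here, and "the series" means these few. Any claim that something is new, unique, unknown or untested is made for them only; others in the source may bear on it.

In a functional assay on KB cells (Homo sapiens) for inhibition (on this read-out higher numbers stand for weaker inhibition and lower numbers for stronger inhibition), compound 1 `N#Cc1c(Br)n(COCc2ccccc2)c2ncnc(N)c12` is reported only as a limit, > 100000 nM. Compound 2 `COCCOCn1c(Br)c(C#N)c2c(N)ncnc21` is likewise reported only as a limit, > 100000 nM, and stands at the limit of > 100000 nM in this assay, at which 2 of the 3 values shown sit. Going by the values given here, the only measured step here is a step that the two limits leave unreadable from compound 1 to compound 2, and it concerns a different part of the structure. Compound 3 `COCCOCn1cc(C(N)=S)c2c(N)ncnc21` gives an actual number, 183000 nM. Compound 4 `CNc1c(C#N)c2c(N)ncnc2n1COCCOC` carries methylamino in place of bromo on an aromatic carbon, (methylamino in place of bromo on an aromatic carbon). Among the compounds with values here, no measured step covers this change, so the expectation rests only on where compound 2 stands. The expected step that the limit leaves unreadable from compound 2 to compound 4 is no change beyond the scatter. The estimate for compound 4 is 120000 nM, with an expected range of 40000 nM to 300000 nM.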

Compound 4, half-maximal inhibitory concentration: > 100000 nM
Compound 4: only a limit was reported; the forecaster's own chance of this, stated with the estimate: 70%; the middle value does not contradict the limit.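

In this assay compound 4 is reported only as a limit, > 100000 nM. Compound 2 is also a limit, so no step can be read between them. The compounds shown leave open whether methylamino in place of bromo changes inhibition at all.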